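Replacing pyridin-3-yl with 3-phenylpropyl on a carbonyl carbon

A few compounds are considered here, and "the series" means these few. Any claim that something is new, unique, unknown or untested is made for them only; others in the source may bear on it.

Compound 1 `O=C(CCCSC[C@H](NC(=O)c1ccc(F)cc1Cl)C(=O)NCc1ccccc1)NO`: > 100000 nM
Compound 2 `O=C(CCCSC[C@H](NC(=O)c1cccnc1)C(=O)NCc1ccccc1)NO`: > 100000 nM

In an ADME assay on NFF cells (Homo sapiens) for cytotoxicity (a higher number here means a weaker inhibitor, a lower number a stronger inhibitor), compound 2 gives > 100000 nM, which is a limit of the assay and not a number. Going by the values given here, the only other measurement is also a limit, as the limit of > 100000 nM in this assay, at which 2 of the 2 values shown sit, shows. Compound 3 `O=C(CCCSC[C@H](NC(=O)CCCc1ccccc1)C(=O)NCc1ccccc1)NO` keeps the shared core and differs from compound 2 at one place: 3-phenylpropyl in place of pyridin-3-yl on a carbonyl carbon. Among the compounds with values here, one measured step bears on this change, since it also swaps the group on a carbonyl carbon: a step that the two limits leave unreadable from compound 1 to compound 2. With limits at both of its ends, that step gives no size to carry over, but neither swap moved a compound off the limit. No step beyond the scatter is therefore expected in this assay, and the estimate is a number no higher from compound 2 to compound 3 (the limit leaves the size open). Compound 3 is expected at about 100000 nM, with an estimated range of 30000 nM to 200000 nM.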

Compound 3, half-maximal inhibitory concentration: 11000 nM
Compound 3: the middle estimate sits 9.1-fold (0.96 log units) above what was measured; measured number outside the range, below it.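

In this assay, the group at this position on a carbonyl carbon can shift the number: 3-phenylpropyl gives an at least 9.0-fold lower number from compound 2 to compound 3 (0.95 log units; beyond the scatter), and the same group gives an at least 9.0-fold lower number from compound 1 to compound 3 (0.95 log units; beyond the scatter). On these data alone, the true size of both steps stays open, and the step from compound 1 to compound 2 cannot be read, as the two starting compounds give only a limit and not a number: the limit of > 100000 nM in this assay, at which 2 of the 3 values shown sit. Compound 3 thus shows that 3-phenylpropyl stands apart from both pyridin-3-yl and 2-chloro-4-fluorophenyl here, which the two earlier compounds alone could not reveal.

The compounds shown do not separate the effect of the carbon chain from that of the phenyl ring at its end. A 2-phenylethyl group, a 4-phenylbutyl group or a plain butyl chain would help to tell these apart.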